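Chloro to methoxy on compound 2

This account rests on a few compounds, and the source may have more. Where it says the series, first, only, none or still open, it means among the compounds named here.

In a functional assay on A549 cells (Homo sapiens) for antiproliferative activity, read by MTT assay, with a stated time of 48 h (on this read-out lower numbers stand for stronger inhibition and higher numbers for weaker inhibition), compound 2 (`Cc1ccc(/C=C/C(=O)Nc2nnc(-c3ccc(Cl)cc3)s2)cc1`) gives 1.25 ug/mL and lies within the scatter of compound 1 (`Cc1ccc(-c2nnc(NC(=O)/C=C/c3ccc(C(F)(F)F)cc3)s2)cc1`) at 1.61 ug/mL in that read-out. Compound 3 (`O=C(/C=C/c1ccc(C(F)(F)F)cc1)Nc1nnc(-c2ccc(Br)cc2)s1`) reads 4.68 ug/mL and stands higher than compound 2, beyond the scatter. Compound 4 (`COc1ccc(-c2nnc(NC(=O)/C=C/c3ccc(C)cc3)s2)cc1`) carries methoxy in place of chloro on an aromatic carbon and is otherwise the same as compound 2. Among the compounds with values here, the one measured step that bears on this, bromo in place of methyl, is modest at a 2.9-fold higher number from compound 1 to compound 3 (0.46 log units; beyond the scatter) but involves a different pair of groups, so it sets no direction. The expected step is a 1.2-fold higher number from compound 2 to compound 4 (0.08 log units; within the scatter) and none beyond the scatter is anticipated in this assay for this change. Compound 4 is estimated at 1.5 ug/mL with an expected range from 0.5 ug/mL to 4.5 ug/mL in this measurement.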

Compound 4, half-maximal inhibitory concentration: 0.58 ug/mL
Compound 4: middle estimate off by 2.6-fold (0.41 log units), on the high side; the measured number falls inside the stated range.
By their numbers in this assay, from the lowest: compound 4; then compounds 2 and 1 (each within the scatter of the next); then compound 3.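

In this assay the change from 4-chlorophenyl to 4-methoxyphenyl gives a 2.2-fold lower number from compound 2 to compound 4 (0.33 log units; beyond the scatter) and so shows that methoxy at this place, para to a large group, can lower the number beyond the scatter. The earlier step at this place, a 2.9-fold higher number from compound 1 to compound 3 (0.46 log units; beyond the scatter) for a different pair of groups, went upward, so the number here can move either way. Nothing available explains the fall. From the compounds shown here alone, whether an amine or a hydroxy group here would lower the number further stays open, as does whether methoxy gives a like step in a compound carrying trifluoromethyl.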